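Cytotoxicity notes: acyl variation on the aniline nitrogen

A few compounds are considered here, and "the series" means these few. Any claim that something is new, unique, unknown or untested is made for them only; others in the source may bear on it.

Measured compounds:
compound 1 `CC(=O)Nc1ccc(-c2nc3cc(C(F)(F)F)ccc3n2C)cc1`: > 100000 nM
compound 2 `Cn1c(-c2ccc(N)cc2)nc2cc(C(F)(F)F)ccc21`: > 100000 nM

In an ADME assay on Vero cells (Chlorocebus sabaeus) for cytotoxicity (a higher number here means that more compound is tolerated, a lower number that less compound is tolerated), compound 1 reaches only the limit of the assay, > 100000 nM. For compound 2 the same assay likewise gives only a limit, > 100000 nM. The step that the two limits leave unreadable from compound 1 to compound 2 therefore cannot be read, and compound 2 stands at the limit of > 100000 nM in this assay, at which 2 of the 2 values shown sit, with no number of its own.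

Compound 3 `CCC(=O)Nc1ccc(-c2nc3cc(C(F)(F)F)ccc3n2C)cc1` is the next member. Relative to compound 2 it carries propanoyl in place of hydrogen on a nitrogen on an aromatic ring. For the measured compounds named here, the only step that bears on this change, a step that the two limits leave unreadable from compound 1 to compound 2, is itself unreadable; what the two values show is that both sit at the limit. Compound 1, which carries acetyl at the same nitrogen, already reaches the limit, so no step beyond the scatter is expected for compound 3 in this assay, a step that the limit leaves unreadable from compound 2 to compound 3. Compound 3 is estimated at 150000 nM, range 70000 nM to 400000 nM, most likely again reported as a limit.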

Compound 3, half-maximal cytotoxic concentration: > 100000 nM
Compound 3 gave a limit, no number; the forecaster's own chance of this, stated with the estimate: 85%; the middle value lies beyond the limit too.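

In this assay compound 3 gives > 100000 nM, again a limit and not a number. The steps from compound 1 and compound 2 to compound 3 therefore cannot be read: the limit of > 100000 nM in this assay, at which 3 of the 3 values shown sit.

The compounds shown leave open at what concentration, if any, the free amine or either acyl group becomes cytotoxic in this assay.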